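A 3-Bromobenzyl Group on the Core of Compound 1

This account rests on a few compounds, and the source may have more. Where it says the series, first, only, none or still open, it means among the compounds named here.

Measured in a functional assay on BV-2 cells (Mus musculus), read by Griess assay, with a stated time of 24 h; a lower number here means a stronger inhibitor, a higher number a weaker inhibitor:
compound 1 `O=C1C=CC2(C=C1)OCCC(=O)N2c1ccccc1`: 1300 nM
compound 2 `C=CCC1COC2(C=CC(=O)C=C2)N(c2ccccc2)C1=O`: 1030 nM
compound 3 `C=C(C)CC1COC2(C=CC(=O)C=C2)N(c2ccccc2)C1=O`: 450 nM

Compound 1 gives the highest of the three numbers, its nearest neighbour being compound 2, its furthest compound 3. Compound 4 `O=C1C=CC2(C=C1)OCC(Cc1cccc(Br)c1)C(=O)N2c1ccccc1` differs from compound 1 by 3-bromobenzyl in place of hydrogen on a saturated ring carbon. Among the compounds with values here, two measured steps bear on this change, both adding a chain at the same saturated ring carbon: a 1.3-fold lower number from compound 1 to compound 2 (0.10 log units; within the scatter) and a 2.9-fold lower number from compound 1 to compound 3 (0.46 log units; beyond the scatter). Within the data shown here, the larger chain brought the larger, though modest, drop; no step with an aromatic group is known. A modest lowering is therefore expected, a 2.6-fold lower number from compound 1 to compound 4 (0.41 log units; beyond the scatter). Compound 4 is estimated at 500 nM, with a range from 200 nM to 1500 nM.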

Compound 4, half-maximal inhibitory concentration: 540 nM
Estimate against measurement, compound 4: 1.1-fold (0.03 log units) below, and the stated range covers the measured number.
By their numbers in this assay, from the lowest: compounds 3, 4, 2 and 1 (each within the scatter of the next, the first and the last beyond it).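

In this assay a chain bearing an aromatic ring at this saturated ring carbon gives a 2.4-fold lower number from compound 1 to compound 4 (0.38 log units; beyond the scatter) and so lies beyond the scatter. The position therefore takes 3-bromobenzyl as well as the alkenyl chains, with a 1.2-fold higher number from compound 3 to compound 4 (0.08 log units; within the scatter) and a 1.9-fold lower number from compound 2 to compound 4 (0.28 log units; within the scatter) both within the scatter. Nothing given here accounts for these numbers. From the compounds shown here alone, what an amine or a carboxylic acid on this chain would do stays open, and so does what the bromine of the 3-bromobenzyl group contributes.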